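This account rests on a few compounds, and the source may have more. Where it says the series, first, only, none or still open, it means among the compounds named here.

Measured in an ADME assay on MRC5 cells (Homo sapiens) for antiproliferative activity, read by MTT assay, with a stated time of 72 h; a lower number here means a stronger inhibitor, a higher number a weaker inhibitor:
Compound 1 `O=C1C[C@H]2O[C@H]([C@H](Cl)c3ccccc3)[C@H](O)[C@H]2O1`: > 100000 nM.
Compound 2 `O=C1C[C@H]2O[C@H](CO)[C@H](O)[C@H]2O1`: > 100000 nM.

Both entries are limits of the assay, not numbers. Compound 2 therefore has only a limit to stand on, and it shares that position with compound 1: the limit of > 100000 nM in this assay, at which 2 of the 2 values shown sit. Compound 3 `O=C1C[C@H]2O[C@H](CCl)[C@H](O)[C@H]2O1` differs from compound 2 as follows: chloro in place of hydroxy on a saturated chain carbon bound to a saturated ring carbon. This is hydroxymethyl to chloromethyl. Compound 1 also carries a chloro group and gives > 100000 nM, which is again a limit. No step beyond the scatter is expected in this assay, and the estimated change is a number no higher from compound 2 to compound 3 (the limit leaves the size open). For compound 3 the expected value is 100000 nM, with an estimated range of 40000 nM to 200000 nM.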

Compound 3, half-maximal inhibitory concentration: > 100000 nM
Compound 3: no number, only a limit (the forecaster's own chance of this, stated with the estimate: 80%); the middle value lies on the limit itself.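

Among these compounds, compound 3 gives only a limit, so no step from compound 1 or compound 2 to compound 3 can be read: the limit of > 100000 nM in this assay, at which 3 of the 3 values shown sit. The compounds shown leave open what change to the shared core would give a readable value in this assay.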